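The compounds below may be only part of what the source reports. "The series", "measured", "known", "first", "only" and "open" are said of these compounds alone.

Measured so far:
- compound 1, `CCN(CC)CCNC(=O)c1ccc(C(CC)(CC)c2ccc(OCCC(O)(CC)CC)c(C)c2)n1CC`, in an assay on isolated protein for displacement of a labelled ligand from vitamin D3 receptor (Homo sapiens), read by fluorescence polarization, with a stated time of 4 h (a lower number here means a stronger inhibitor, a higher number a weaker inhibitor), compound 1 gives 271 nM
- compound 2, `CCn1c(C(=O)NCC#N)ccc1C(CC)(CC)c1ccc(OCCC(O)(CC)CC)c(C)c1`, in this assay compound 2 gives 825 nM

Among the measured compounds shown here, compound 2 holds the highest of the two numbers in this assay; its nearest neighbour is compound 1, and the single step between them, a 3.0-fold higher number from compound 1 to compound 2 (0.48 log units; beyond the scatter), is the only measured step.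

Compound 3, `CCOc1ccc(NC(=O)c2ccc(C(CC)(CC)c3ccc(OCCC(O)(CC)CC)c(C)c3)n2CC)cc1`, is not yet measured. It differs from compound 2 in one place: 4-ethoxyphenyl in place of cyanomethyl on an amide-type nitrogen. The change sits on the same amide-type nitrogen that was varied in the step from compound 1 to compound 2, so that step is the only one bearing on it. There, exchanging the (diethylamino)methyl for cyano raised the number by a modest, beyond-scatter amount. For the measured compounds named here, no measured pair shows an aromatic group on this nitrogen, so the direction of the present change is uncertain; a return toward the value of compound 1 is plausible but unsupported by any direct comparison.

On that basis compound 3 is expected to give 400 nM in this assay, with a range of 150 nM to 1200 nM, an estimated step of a 2.1-fold lower number from compound 2 to compound 3 (0.31 log units; beyond the scatter).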

Compound 3, half-maximal inhibitory concentration: 4540 nM
Beside the measured number, compound 3's estimate is 11-fold (1.05 log units) below it, outside the stated range (above it).
By their numbers in this assay, from the lowest: compound 1; then compound 2; then compound 3.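

Among the compounds shown here, on the amide-type nitrogen, 4-ethoxyphenyl is the first aromatic group seen, and in this assay it moves the result the wrong way: the change gives a 5.5-fold higher number from compound 2 to compound 3 (0.74 log units; beyond the scatter), and the comparison with the basic-chain compound gives a 17-fold higher number from compound 1 to compound 3 (1.22 log units; beyond the scatter). The position is therefore clearly not indifferent to its substituent, since the order from the lowest number now runs 2-(diethylamino)ethyl, cyanomethyl, 4-ethoxyphenyl, and the aromatic group costs more than the earlier exchange did, which was a 3.0-fold higher number from compound 1 to compound 2 (0.48 log units; beyond the scatter). Nothing on hand accounts for this rise in the number.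

On these data alone, the entering group differs from cyanomethyl both in size, with 9 heavy atoms against 3, and in its six-membered aromatic ring, so it remains open whether the ring itself or its ethoxy group goes with the weaker result, a question that an unsubstituted phenyl or a benzyl group on the same nitrogen would address. Also open, as far as these compounds go, is whether the lowest number, held by compound 1, depends on its diethylamino group, which a plain butyl chain or a morpholine-bearing ethyl chain at this nitrogen would test.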